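This account rests on a few compounds, and the source may have more. Where it says the series, first, only, none or still open, it means among the compounds named here.

Measured so far in an assay on isolated protein for binding affinity to sphingosine 1-phosphate receptor 2 (Homo sapiens), read by surface plasmon resonance; a lower number here means tighter binding, a higher number weaker binding:

Compound 1, `COc1ccc(-c2cc(NNC(=O)Nc3cc(Cl)nc(Cl)c3)nc3c2c(C)nn3C)cc1`: 1020 nM
Compound 2, `Cn1ncc2c(-c3ccccc3)cc(NNC(=O)Nc3cc(Cl)nc(Cl)c3)nc21`: 1020 nM
Compound 3, `CCN(CC)c1cc(NC(=O)NNc2cc(-c3ccc(F)cc3)c3cnn(C)c3n2)cc(Cl)n1`: 3150 nM

Three compounds of the series carry a number in this assay. Compound 3 gives the highest of the three; compound 1 and compound 2 both sit lower, and the gap from compound 3 to each of them lies beyond the scatter. Compound 1 and compound 2 fall within the scatter of one another, so nothing separates them on present numbers.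

Compound 4, `CCCCOc1cc(NC(=O)NNc2cc(-c3ccc(F)cc3)c3cnn(C)c3n2)cc(Cl)n1`, is not yet measured. It differs from compound 3 in one place: butoxy in place of diethylamino on an aromatic carbon. The group that leaves and the group that enters match in heavy-atom count and in donor and acceptor count. Among the compounds with values here, no measured pair exchanges these two groups, so the direction of the step cannot be read from existing data; the only anchor is the value of compound 3, 3150 nM, and the expectation is a step of about the size of the scatter, a 1.1-fold lower number from compound 3 to compound 4 (0.02 log units; within the scatter), with no firm direction. For compound 4 the estimated value in this assay is 3000 nM, with a range from 1000 nM to 9000 nM.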

Compound 4, dissociation constant: 2650 nM
The estimate for compound 4 lay 1.1-fold (0.05 log units) above the measured number; the range from low to high includes it.
By their numbers in this assay, from the lowest: compounds 1 and 2 (each within the scatter of the next); then compounds 4 and 3 (each within the scatter of the next).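

In this assay, within the data shown here, exchanging diethylamino for butoxy on the aromatic carbon next to the ring nitrogen gives a 1.2-fold lower number from compound 3 to compound 4 (0.08 log units; within the scatter), and this is the only one-place comparison available. The two groups match in heavy-atom count and in hydrogen-bond donor and acceptor count, yet they attach through different atoms, nitrogen in diethylamino and oxygen in butoxy, and this single pair shows no separation between them in this assay. No supporting evidence bears on why the two groups read alike, so the result stands as an observation on one pair.

On these data alone, it remains open whether a markedly different group at this position, such as a primary amine, a carboxylic acid, a methoxy group or a longer alkoxy chain, would shift the number beyond the scatter. As far as these compounds go, it is also open whether the exchange of diethylamino for butoxy would read the same way on the core of compound 1, so the observation cannot yet be extended beyond the pair of compound 3 and compound 4.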